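Hydroxy to dimethylamino on a solubility read-out

The compounds below may be only part of what the source reports. "The series", "measured", "known", "first", "only" and "open" are said of these compounds alone.

In a physicochemical assay for solubility, read by LC-MS, in phosphate buffer, with a stated time of 24 h, at pH 7.4 (on this read-out lower numbers stand for lower solubility and higher numbers for higher solubility), compound 1 (`CN(c1ncco1)c1cnc(NCc2c(F)ccc3c2CCO3)n2cnnc12`) gives 67000 nM and compound 2 (`O=C1c2ccccc2CN1c1cnc(NCc2c(F)ccc3c2CCO3)n2cnnc12`) gives 4000 nM. Compound 3 (`Cc1nc(CO)ccc1-c1cnc(NCc2c(F)ccc3c2CCO3)c2cn[nH]c(=O)c12`) gives 3000 nM, within the scatter of compound 2 and far under compound 1. Compound 4 (`Cc1nc(CN(C)C)ccc1-c1cnc(NCc2c(F)ccc3c2CCO3)c2cn[nH]c(=O)c12`) carries dimethylamino in place of hydroxy on a saturated chain carbon bound to an aromatic carbon. Within the data shown here, no measured step covers this change. The only one, a 17-fold lower number from compound 1 to compound 2 (1.22 log units; beyond the scatter), exchanges other groups on an aromatic carbon of a different core, so it shows only that large moves occur in this assay. A modest upward move is expected, with weak support: a 2.7-fold higher number from compound 3 to compound 4 (0.43 log units; beyond the scatter). For compound 4 the estimated value is 8000 nM, with an expected range of 2500 nM to 30000 nM.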

Compound 4, solubility: > 1000000 nM
Compound 4 ended at the assay's limit (the forecaster's own chance of this, stated with the estimate: 2%); at least 120-fold (2.09 log units) between middle value and limit.
By their numbers in this assay, from the lowest: compounds 3 and 2 (each within the scatter of the next); then compound 1. At a limit, above all of these: compound 4.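

On the saturated chain carbon bound to an aromatic carbon, dimethylamino in place of hydroxy gives an at least 330-fold higher number from compound 3 to compound 4 (2.52 log units; beyond the scatter), so a change confined to this side chain, with the shared core untouched, can move the number strongly upward. Among these compounds, the only earlier step, on an aromatic carbon, went down and joined compounds with different cores. Compound 4 gives > 1000000 nM, which is a limit and not a number, so the full size of this step stays unknown: the limit of > 1000000 nM in this assay, at which 1 of the 4 values shown sits.

From the compounds shown here alone, whether the rise is particular to dimethylamino remains open. A primary amine, a carboxylic acid or a longer chain carrying dimethylamino at this place could separate these possibilities.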